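Aryl swap on compound 2 at the assay limit

The source may report more compounds than this note shows. Statements on the series, on what has been measured and on what is new or still open speak of the compounds shown alone.

In an ADME assay on MIA PaCa-2 cells (Homo sapiens) for cytotoxicity, read by MTT assay, with a stated time of 72 h (a higher number here means a weaker inhibitor, a lower number a stronger inhibitor), compound 2 (`COc1ccc(OC)c(C2=C(c3cc(OC)c(OC)c(OC)c3)C(=O)CC2O[SiH2]C(C)(C)C)c1`) gives > 100 ug/mL, which is a limit and not a number. Compound 1 (`COc1ccc(C2=C(c3cc(OC)c(OC)c(OC)c3)C(=O)C(OC(C)=O)C2)cc1OC(C)C`) gives > 100 ug/mL, also a limit. Compound 3 (`COc1ccc(OC)c(C2=C(c3cc(OC)c(OC)c(OC)c3)C(=O)CC2O)c1`) gives > 100 ug/mL, again a limit. For the measured compounds named here, the series so far therefore sits at the limit of > 100 ug/mL in this assay, at which 3 of the 3 values shown sit.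

Compound 4 (`COCOc1cc(C2=C(c3cc(OC)c(OC)c(OC)c3)C(=O)CC2O[SiH2]C(C)(C)C)ccc1OC`) differs from compound 2 by 4-methoxy-3-(methoxymethoxy)phenyl in place of 2,5-dimethoxyphenyl on a double-bonded ring carbon. Going by the values given here, the only measured step is a step that the two limits leave unreadable from compound 2 to compound 3, which involves the oxygen on a saturated carbon rather than the double-bonded ring carbon and has no readable size. On that step alone, no step beyond the scatter is expected in this assay, and another limit is the likeliest report. The expected change is a number no higher from compound 2 to compound 4 (the limit leaves the size open). For compound 4 the estimated value is 100 ug/mL, with an expected range of 30 ug/mL to 300 ug/mL.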

Compound 4, half-maximal inhibitory concentration: 50 ug/mL
The estimate for compound 4 lay 2.0-fold (0.30 log units) above the measured number; the measured number falls inside the stated range.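

In this assay, 4-methoxy-3-(methoxymethoxy)phenyl in place of 2,5-dimethoxyphenyl on the double-bonded ring carbon gives an at least 2.0-fold lower number from compound 2 to compound 4 (0.30 log units; that floor lies within the scatter). Compound 4 gives 50 ug/mL, the only number shown that is not a limit, so this aryl group is a place where a readable value appears. The other compounds stay at the limit: the limit of > 100 ug/mL in this assay, at which 3 of the 4 values shown sit.

Going by these compounds, the true size of the step stays open, as does which part of the aryl swap carries it. Also open, on these data alone, is what an amine or a carboxylic acid in place of the methoxymethoxy group would give.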